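The source may report more compounds than this note shows. Statements on the series, on what has been measured and on what is new or still open speak of the compounds shown alone.

In a physicochemical assay for lipophilicity, at pH 7.4 (a lower number here means a more polar compound, a higher number a more lipophilic compound), compound 1 (`CNCc1ccc2nc(NC(=O)c3ccc(C(C)(C)C)cc3)cn2c1`) gives 2.4 and compound 2 (`CC(C)(C)c1ccc(C(=O)Nc2cn3cc(F)ccc3n2)cc1`) gives 3.55. Compound 3 (`CC(C)(CO)c1ccc(C(=O)Nc2cn3cc(-n4ccnc4)ccc3n2)cc1`) gives 1.62, the lowest of the three numbers. Compound 1 stands nearest above it and compound 2 furthest, both beyond the scatter.

Compound 4 (`CC(C)(O)c1ccc(C(=O)Nc2cn3cc(-n4ccnc4)ccc3n2)cc1`) has not yet been measured. It differs from compound 3 in one place: hydroxy in place of hydroxymethyl on a saturated chain carbon bound to an aromatic carbon and two saturated chain carbons. This is hydroxy in place of hydroxymethyl, on a saturated chain carbon bound to an aromatic carbon and two saturated chain carbons.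

Among the measured compounds shown here, only one measured step is available: a number 1.15 log units higher from compound 1 to compound 2 (beyond the scatter). That step is large, but it exchanges fluoro for (methylamino)methyl on an aromatic carbon, so it involves other groups at another kind of place. It shows how far one exchange can move the number in this series, but it gives no direct size for the present change. For the measured compounds named here, no measured pair isolates hydroxymethyl against hydroxy, so the estimate starts from compound 3 at 1.62 and remains uncertain. The expected step is a number 0.17 log units lower from compound 3 to compound 4 (within the scatter), a slight move to a lower number that stays within the scatter. Compound 4 is estimated at 1.45, with an expected range from 1.1 to 1.8.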

Compound 4, distribution coefficient: 1.27
Estimate against measurement, compound 4: 0.18 log units above; the measured number falls inside the stated range.
By their numbers in this assay, from the lowest: compound 4; then compound 3; then compound 1; then compound 2.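

In this assay, among the compounds shown here, the change from 1-(hydroxymethyl)-1-methylethyl to 1-hydroxy-1-methylethyl gives a number 0.35 log units lower from compound 3 to compound 4 (beyond the scatter), the first measured step at a saturated chain carbon rather than an aromatic carbon. It shows that this place is not silent: removing one carbon while the hydrogen-bond donor and acceptor counts stay the same still moves the number modestly, and to a lower value, although this rests on a single pair and sets no general trend. The data offer no explanation for the size or direction of this step.

Still open, as far as these compounds go, is how an amine, a methoxy group or a carboxylic acid on the same saturated chain carbon would stand against hydroxy and hydroxymethyl, and whether a longer chain carrying the hydroxy would continue the move seen here. Also open, from the compounds shown here alone, is whether the same exchange gives a step of similar size and direction when fluoro or (methylamino)methyl, rather than the group shared by compound 3 and compound 4, sits on the core.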